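A few compounds are considered here, and "the series" means these few. Any claim that something is new, unique, unknown or untested is made for them only; others in the source may bear on it.

Compound 1 `COC(=O)N(C)C(C)C#CCN1CCCC1` is the reference, and in a functional assay on the whole organism for agonist activity, with Mus musculus as the target (on this read-out lower numbers stand for an effect already at smaller amounts and higher numbers for an effect only at larger amounts of compound), compound 1 gives 20.9 mg/kg. Compound 2 `COC(=O)N(C)C(C)C#CCn1ccnc1` differs from it by 1H-imidazol-1-yl in place of pyrrolidin-1-yl on a saturated chain carbon bound to a triple-bonded carbon, and in this assay compound 2 gives 8 mg/kg, so that a 2.6-fold lower number from compound 1 to compound 2 (0.42 log units; beyond the scatter). Compound 3 `CCOC(=O)N(C)C(C)C#CCN1CCCC1` differs from compound 1 by methyl in place of hydrogen on a saturated chain carbon bound to an oxygen next to a carbonyl group. In this assay compound 3 reaches only a limit of the assay, > 100 mg/kg. Hence an at least 4.7-fold higher number from compound 1 to compound 3 (0.67 log units; beyond the scatter), a step that rests on (the limit of > 100 mg/kg in this assay, at which 1 of the 3 values shown sits). Compound 4 `CCOC(=O)N(C)C(C)C#CCn1ccnc1` is not yet measured and differs from compound 3 by 1H-imidazol-1-yl in place of pyrrolidin-1-yl on a saturated chain carbon bound to a triple-bonded carbon, the same change that separates compound 1 from compound 2. The step from compound 3 to compound 4 is expected to be an at least 2.0-fold lower number from compound 3 to compound 4 (0.30 log units; that floor lies within the scatter). That expectation rests on the step of a 2.6-fold lower number from compound 1 to compound 2 (0.42 log units; beyond the scatter) made by the same change, though the starting point is itself only a limit. Compound 4 is therefore expected to give about 50 mg/kg in this assay, between 20 mg/kg and 200 mg/kg.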

Compound 4, dose for half-maximal effect: > 100 mg/kg
Compound 4 gave a limit, no number; the forecaster's own chance of this, stated with the estimate: 45%; middle value at least 2.0-fold (0.30 log units) from the limit.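

Compound 3 and compound 4 both stand at a limit of the assay, and the step between them cannot be read, so it is not shown whether 1H-imidazol-1-yl in place of pyrrolidin-1-yl carries over from the core of compound 1 to the core of compound 3. Methyl in place of hydrogen gives an at least 12-fold higher number from compound 2 to compound 4 (1.09 log units; beyond the scatter). This change points the same way on both cores, but its size cannot be compared between them: the same change on two cores in this assay, an at least 4.7-fold higher number (0.67 log units; beyond the scatter) from compound 1 to compound 3 and an at least 12-fold higher number (1.09 log units; beyond the scatter) from compound 2 to compound 4; the limit leaves it open whether they differ

The compounds shown leave open how piperidin-1-yl in place of pyrrolidin-1-yl, on a saturated chain carbon bound to a triple-bonded carbon, would read in this assay. They also leave open whether any replacement at that place would bring the larger core of compound 3 back from the limit.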